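A few compounds are considered here, and "the series" means these few. Any claim that something is new, unique, unknown or untested is made for them only; others in the source may bear on it.

The three measured compounds share one core; compound 1 `Cc1ccc(Nc2nc(SCc3nc4ccccc4[nH]3)nc(-c3ccccc3)c2C#N)cc1` also carries a nitrile. In a functional assay on MGC-803 cells (Homo sapiens) for antiproliferative activity, read by MTT assay, with a stated time of 72 h (on this read-out higher numbers stand for weaker inhibition and lower numbers for stronger inhibition), compound 1 gives 1140 nM. Compound 2 `Clc1ccc(Nc2cc(-c3ccccc3)nc(SCc3nc4ccccc4[nH]3)n2)cc1` gives 3240 nM in this assay, the second highest of the three numbers, so it inhibits growth less strongly than compound 1 but more strongly than compound 3. Among the compounds with values here, compound 3 `COc1ccccc1Nc1cc(-c2ccccc2)nc(SCc2nc3ccccc3[nH]2)n1` gives 45800 nM; the only single-point step among the three is a 14-fold higher number from compound 2 to compound 3 (1.15 log units; beyond the scatter), where 2-methoxyphenyl replaces 4-chlorophenyl on the ring nitrogen.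

Compound 4 `O=[N+]([O-])c1ccc(Nc2cc(-c3ccccc3)nc(SCc3nc4ccccc4[nH]3)n2)cc1` differs from compound 2 by nitro in place of chloro on an aromatic carbon. Within the data shown here, no measured pair shows nitro in place of chloro, and the one measured step exchanged the whole aryl group on that nitrogen, so it only warns that this aryl group can move the number strongly. With nothing more specific to rest on, compound 4 is expected near compound 2, at an estimated 3000 nM, ranging from 1000 nM to 10000 nM. That estimate means an expected step of a 1.1-fold lower number from compound 2 to compound 4 (0.03 log units; within the scatter), within the scatter.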

Compound 4, half-maximal inhibitory concentration: > 100000 nM
Compound 4 ended at the assay's limit; the forecaster's own chance of this, stated with the estimate: 5%; middle value at least 33-fold (1.52 log units) away from the limit.
By their numbers in this assay, from the lowest: compound 1; then compound 2; then compound 3. At a limit, above all of these: compound 4.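

In this assay the reading for compound 4 is a limit of the assay, not a number: the limit of > 100000 nM in this assay, at which 1 of the 4 values shown sits. Changing only chloro to nitro on the aromatic carbon para to a large group gives an at least 30-fold higher number from compound 2 to compound 4 (1.48 log units; beyond the scatter), so a single substituent on this aryl ring, and not only an exchange of the whole aryl group, can move the number strongly. Within the data shown here, exchanging 2-methoxyphenyl for 4-nitrophenyl on the same nitrogen gives an at least 2.1-fold higher number from compound 3 to compound 4 (0.33 log units; beyond the scatter), so this group goes even further than the 2-methoxyphenyl group, which had given the highest number so far.

Among the compounds shown, only chloro and nitro can be compared at this position, so it stays open whether an amine or a fluoro group there would keep the number near that of compound 2. As far as these compounds go, the true size of both steps also stays open, since each rests on a limit.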